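Removing the methoxy group: compound 3 to compound 4

A few compounds are considered here, and "the series" means these few. Any claim that something is new, unique, unknown or untested is made for them only; others in the source may bear on it.

Three compounds share one core and differ at a single aromatic carbon. Compound 1 `CC1=NNC(=O)C1C(c1c(-c2ccccc2)[nH]c2ccc(C)cc12)c1c(-c2ccccc2)[nH]c2ccc(C)cc12` carries a methyl there; in a functional assay on HEp-2 cells (Homo sapiens) for cytotoxicity, read by MTT assay (a lower number here means a stronger inhibitor, a higher number a weaker inhibitor), compound 1 reaches only the assay's limit of > 100000 nM. Compound 2 `CC1=NNC(=O)C1C(c1c(-c2ccccc2)[nH]c2ccc(C)cc12)c1c(-c2ccccc2)[nH]c2ccc(Cl)cc12` carries a chloro and gives 32400 nM. Compound 3 `COc1ccc2[nH]c(-c3ccccc3)c(C(c3c(-c4ccccc4)[nH]c4ccc(C)cc34)C3C(=O)NN=C3C)c2c1` carries a methoxy and gives 3500 nM, the lowest of the two numbers shown, with compound 2 nearest. Both steps toward the methoxy, an at least 28-fold lower number from compound 1 to compound 3 (1.45 log units; beyond the scatter) and a 9.3-fold lower number from compound 2 to compound 3 (0.97 log units; beyond the scatter), lowered the number. Compound 4 `CC1=NNC(=O)C1C(c1c(-c2ccccc2)[nH]c2ccccc12)c1c(-c2ccccc2)[nH]c2ccc(C)cc12` removes that group: hydrogen in place of methoxy on an aromatic carbon. The reverse move is therefore expected to raise the number, by an 8.6-fold higher number from compound 3 to compound 4 (0.93 log units; beyond the scatter). Compound 4 is estimated at 30000 nM, within 8000 nM to 100000 nM.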

Compound 4, half-maximal inhibitory concentration: > 100000 nM
Compound 4: a limit, no number; the forecaster's own chance of this, stated with the estimate: 25%; at least 3.3-fold (0.52 log units) between middle value and limit.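

Compound 4 reaches only a limit of the assay, not a number, the same limit as the methyl compound: the limit of > 100000 nM in this assay, at which 2 of the 4 values shown sit.

With hydrogen on this carbon, the low number of compound 3 is lost, with an at least 28-fold higher number from compound 3 to compound 4 (1.45 log units; beyond the scatter), and the chloro compound also stands apart, with an at least 3.0-fold higher number from compound 2 to compound 4 (0.48 log units; beyond the scatter). So among these four compounds, only methoxy and chloro bring a number below the limit, while the step between the two limit values cannot be read.

Still open, from the compounds shown here alone, is whether a hydroxyl, an amine or a longer chain such as ethoxy on this carbon would lower the number further than methoxy. Hydrogen and methyl also remain unordered here.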